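Replacing a nitrophenyl with indazolyl on a triazine core

This account rests on a few compounds, and the source may have more. Where it says the series, first, only, none or still open, it means among the compounds named here.

Compounds measured so far:
compound 1, `CCN(CC)c1nc(Nc2cccc(Cl)c2)nc(OC(C(F)(F)F)C(F)(F)F)n1`, giving 2800 nM;
compound 2, `CCN(CC)c1nc(Nc2cccc([N+](=O)[O-])c2)nc(OC(C(F)(F)F)C(F)(F)F)n1`, giving 200 nM.

Compound 2 has the lowest of the two numbers measured in an assay on cells for activation of Cystic fibrosis transmembrane conductance regulator (Homo sapiens), read by fluorescence, with stated times of 10 min and 12 s; a higher number here means that more compound is needed for the effect, a lower number that less compound is needed. Going by the values given here, its nearest neighbour is compound 1, and the single step of a 14-fold lower number from compound 1 to compound 2 (1.15 log units; beyond the scatter) separates them, so compound 2 stands clearly apart from compound 1 in this assay.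

Compound 3, `CCN(CC)c1nc(Nc2ccc3cn[nH]c3c2)nc(OC(C(F)(F)F)C(F)(F)F)n1`, is not yet measured. It differs from compound 2 by 1H-indazol-6-yl in place of 3-nitrophenyl on a nitrogen on an aromatic ring. Among the compounds with values here, only the step from compound 1 to compound 2 has been measured, and it concerns a different exchange, nitro for chloro, at the same part of the shared core; it shows that this part of the molecule can move the number a great deal. Within the data shown here, no measured step bears directly on the indazole group. Compound 3 is therefore expected to lose some of the gain seen for compound 2, with an estimated step of a 3.0-fold higher number from compound 2 to compound 3 (0.48 log units; beyond the scatter). The estimate for compound 3 in this assay is 600 nM, with a range from 150 nM to 3000 nM.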

Compound 3, half-maximal effective concentration: 900 nM
Beside the measured number, compound 3's estimate is 1.5-fold (0.18 log units) below it, and the stated range covers the measured number.
By their numbers in this assay, from the lowest: compound 2; then compound 3; then compound 1.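

In this assay, putting 1H-indazol-6-yl in place of 3-nitrophenyl on the nitrogen brings a 4.5-fold higher number from compound 2 to compound 3 (0.65 log units; beyond the scatter). The two-ring group therefore does not reach the number of the nitro compound, even with the same count of heavy atoms and with a hydrogen-bond donor that 3-nitrophenyl lacks. Set against 3-chlorophenyl, the same group still gives a 3.1-fold lower number from compound 1 to compound 3 (0.49 log units; beyond the scatter), so compound 3 ranks neither lowest nor highest of the three, and this position accepts an exchange of the whole aromatic group as well as of a single substituent on it. Nothing available explains why the numbers fall in this order.

The compounds shown leave open whether the indazole ring hydrogen on nitrogen matters at all, which a version carrying a methyl group on that nitrogen could address, and whether a nitrile, a sulfonamide or a carboxylic acid on the phenyl ring could match or pass the nitro group. They also leave open how these aromatic groups would read with other groups on the rest of the shared core, since that part is the same in all three compounds.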